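Adding methoxy to a hydroxyphenyl thiosemicarbazone

A few compounds are considered here, and "the series" means these few. Any claim that something is new, unique, unknown or untested is made for them only; others in the source may bear on it.

Compound 1 `CC1=CC[C@H](C(C)(C)NC(=S)N/N=C/c2ccccc2)CC1` is the starting point; in a functional assay on U-251 cells (Homo sapiens) for inhibition, read by sulforhodamine B assay, with a stated time of 48 h (a higher number here means a weaker inhibitor of growth, a lower number a stronger inhibitor of growth), compound 1 gives 26300 nM. Compound 2 `COc1ccc(/C=N/NC(=S)NC(C)(C)[C@H]2CC=C(C)CC2)cc1` carries one change, (methoxy in place of hydrogen on an aromatic carbon), and in this assay compound 2 gives 11400 nM, which is a 2.3-fold lower number from compound 1 to compound 2 (0.36 log units; beyond the scatter). Compound 3 `CC1=CC[C@H](C(C)(C)NC(=S)N/N=C/c2ccc(O)cc2)CC1` differs from compound 1 by hydroxy in place of hydrogen on an aromatic carbon. In this assay compound 3 reaches only a limit, > 100000 nM, with no exact number. Compound 4 `COc1cc(/C=N/NC(=S)NC(C)(C)[C@H]2CC=C(C)CC2)ccc1O` is not yet measured; it differs from compound 3 by methoxy in place of hydrogen on an aromatic carbon, the same kind of change as from compound 1 to compound 2, though here the place is ortho to a hydroxy group and meta to a large group rather than para to a large group. A step of roughly an at least 1.6-fold lower number from compound 3 to compound 4 (0.22 log units; that floor lies within the scatter) is expected, resting on the earlier 2.3-fold lower number from compound 1 to compound 2 (0.36 log units; beyond the scatter), tempered by the limit of > 100000 nM in this assay, at which 1 of the 3 values shown sits. Compound 4 is estimated at 60000 nM, between 20000 nM and 200000 nM.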

Compound 4, concentration for 50% growth inhibition: 11700 nM
Estimate against measurement, compound 4: 5.1-fold (0.71 log units) above; measured number below the stated range.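

In this assay, methoxy in place of hydrogen on an aromatic carbon lowers the number on both cores, but the new step, an at least 8.5-fold lower number from compound 3 to compound 4 (0.93 log units; beyond the scatter), is larger than the earlier one, so the change carries over in direction and not in size: the same change on two cores in this assay, a 2.3-fold lower number (0.36 log units; beyond the scatter) from compound 1 to compound 2 and an at least 8.5-fold lower number (0.93 log units; beyond the scatter) from compound 3 to compound 4, at least 3.7-fold (0.56 log units) apart, beyond the scatter of two such steps Compound 3 stands at a limit, > 100000 nM, not at an exact number, so only a floor for this step is known: the limit of > 100000 nM in this assay, at which 1 of the 4 values shown sits. The methoxy also sits at a different place here, ortho to a hydroxy group, so these compounds do not separate the influence of the core from that of the place.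

As far as these compounds go, it remains open how methoxy at this same place would behave without the hydroxy group, and whether an ethoxy group or an amine there would give a step of similar size.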